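A few compounds are considered here, and "the series" means these few. Any claim that something is new, unique, unknown or untested is made for them only; others in the source may bear on it.

Compound 3 `COc1ccc(-c2cc(=O)c3c(OC)cc(OC)cc3n2S(=O)(=O)c2cc(F)c(F)c(F)c2)cc1` stands at the top of the numbers shown. In a functional assay on HepG2 cells (Homo sapiens) for antiproliferative activity, with a stated time of 72 h (on this read-out lower numbers stand for an effect already at smaller amounts and higher numbers for an effect only at larger amounts of compound), compound 3 gives > 65500 nM, which is a limit of the assay rather than a number. Its two companions likewise reach only limits. Compound 1 `COC(=O)c1cc(=O)c2c(OC)cc(OC)cc2n1S(=O)(=O)c1ccc(C)cc1` gives > 20000 nM in this assay, a limit. Compound 2 `COc1ccc(-c2cc(=O)c3c(OC)cc(OC)cc3n2S(=O)(=O)c2ccc(C=O)cc2)cc1` gives > 34400 nM in this assay, again a limit. Among the compounds with values here, the one step that can be traced, a step that the two limits leave unreadable from compound 2 to compound 3, is therefore unreadable in size, since the limit of > 34400 nM in this assay, at which 1 of the 3 values shown sits, and the limit of > 65500 nM in this assay, at which 1 of the 3 values shown sits, cap both of its ends, and the limit of > 20000 nM in this assay, at which 1 of the 3 values shown sits, does the same for the remaining compound.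

Compound 4 `COc1ccc(-c2cc(=O)c3c(OC)cc(OC)cc3n2S(=O)(=O)Cc2ccccc2)cc1` differs from compound 3 by benzyl in place of 3,4,5-trifluorophenyl on a sulfonyl sulfur. Within the data shown here, no measured step bears on this change with a readable size: every value shown is a limit, so nothing among the three compounds indicates that a change on the sulfonyl sulfur moves the read-out beyond the scatter. Compound 4 is expected to remain at a limit as well, with an estimate of 60000 nM and a range from 15000 nM to 250000 nM. The expected step is an at least 1.0-fold lower number from compound 3 to compound 4 (0.03 log units; that floor lies within the scatter), which is not taken as a real shift.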

Compound 4, half-maximal effective concentration: > 34400 nM
Compound 4: a limit, no number; the forecaster's own chance of this, stated with the estimate: 80%; the middle value does not contradict the limit.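

In this assay compound 4 gives > 34400 nM, which is a limit. No step can be read from compound 2 or compound 3 to compound 4. The compounds shown leave open whether any group on the sulfonyl sulfur gives a measurable number in this assay.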